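From an Inactive Compound to a Dimethoxyphenyl Neighbour

The source may hold more compounds than are shown below. What is called first, only, known or untested is meant among the compounds shown, and "the series" means these compounds.

In a functional assay on MCF7 cells (Homo sapiens) for cytotoxicity, read by MTT assay, with a stated time of 72 h (a higher number here means a weaker inhibitor, a lower number a stronger inhibitor), compound 2 `COc1ccc(/C=C/C(=O)Nc2cc3c(Nc4ccc(F)c(Cl)c4)ncnc3cc2OC)cc1` is reported as "not active" (no number reported), so it offers no number to start from. Two related compounds do give numbers: compound 1 `O=C(/C=C/c1cccc(Cl)c1Cl)Nc1cc2c(Nc3ccc(F)c(Cl)c3)ncnc2cc1O[C@H]1CCOC1` gives 30100 nM, and compound 3 `COc1ccc(OC)c(/C=C/C(=O)Nc2cc3c(Nc4ccc(F)c(Cl)c4)ncnc3cc2O[C@H]2CCOC2)c1` gives 36300 nM. Compound 4 `COc1cc(/C=C/C(=O)Nc2cc3c(Nc4ccc(F)c(Cl)c4)ncnc3cc2OC)cc(OC)c1` has not yet been measured. It differs from compound 2 at one place, where 3,5-dimethoxyphenyl stands in place of 4-methoxyphenyl on a double-bonded chain carbon bound to a double-bonded chain carbon: 3,5-dimethoxyphenyl in place of 4-methoxyphenyl on a double-bonded chain carbon bound to a double-bonded chain carbon. Among the compounds with values here, the only measured step that bears on this change is a 1.2-fold higher number from compound 1 to compound 3 (0.08 log units; within the scatter), a swap of groups at that same place. It lies within the scatter, but it is indirect evidence, since compounds 1 and 3 also differ from compound 2 elsewhere. No large shift is therefore expected in this assay, and a result with no number would be unsurprising. For compound 4 the estimated value is 40000 nM, with an expected range from 18000 nM to 90000 nM.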

Compound 4, half-maximal inhibitory concentration: 38500 nM
Compound 4: middle estimate off by 1.0-fold (0.02 log units), on the high side, and the stated range covers the measured number.
By their numbers in this assay, from the lowest: compounds 1, 3 and 4 (each within the scatter of the next).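

Compound 2 has no number in this assay and compound 4 does, so no new step can be read between them. The compounds shown leave open how far 3,5-dimethoxyphenyl in place of 4-methoxyphenyl moves the number. Nothing shown offers an explanation for this result.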